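The compounds below may be only part of what the source reports. "The series", "measured", "known", "first", "only" and "open" are said of these compounds alone.

Of the compounds shown here, three have been measured in a functional assay on U-87MG ATCC cells (Homo sapiens) for cytotoxicity, read by MTT assay, with a stated time of 72 h; on this read-out higher numbers stand for weaker inhibition and lower numbers for stronger inhibition. Compound 1 `CN(C)CCn1cnnc1-c1cc(Oc2ccc(NC(=O)N/N=C/c3cccc(Br)c3)cc2F)ccn1` gives 830 nM in this assay. Among the compounds with values here, compound 2 `CN(C)CCn1cnnc1-c1cc(Oc2ccc(NC(=O)N/N=C/c3ccccc3O[N+](=O)[O-])cc2F)ccn1` gives 7150 nM in this assay, and the one step that separates them, an 8.6-fold higher number from compound 1 to compound 2 (0.94 log units; beyond the scatter), sits on the aryl ring attached to the carbon with a double bond to nitrogen. Compound 3 `Cn1ncnc1-c1cc(Oc2ccc(NC(=O)N/N=C/c3ccccc3)cc2F)ccn1` returns only a limit in this assay, > 100000 nM, and no number stands for it. Compound 3 therefore sits at the limit of > 100000 nM in this assay, at which 1 of the 3 values shown sits.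

Compound 4 `CN(C)CCn1cnnc1-c1cc(Oc2ccc(NC(=O)N/N=C/c3ccccc3)cc2F)ccn1` has not yet been measured. It differs from compound 3 in a single place: 4-(2-(dimethylamino)ethyl)-4H-1,2,4-triazol-3-yl in place of 1-methyl-1H-1,2,4-triazol-5-yl on an aromatic carbon. The unsubstituted phenyl on the hydrazone carbon is shared with compound 3, while the triazole with its side chain is shared with compounds 1 and 2. Within the data shown here, no measured pair changes this triazole, so none of the measured steps gives the size of this change directly, and the step from compound 1 to compound 2 concerns a different position. Since the core of compound 4 is that of compounds 1 and 2, a value of compound 4 in the range of those two numbers is expected, meaning a large fall in the number from the limit of compound 3, with the expected step being an at least 33-fold lower number from compound 3 to compound 4 (1.52 log units; beyond the scatter). Compound 4 is estimated to give 3000 nM in this assay, with a range from 700 nM to 20000 nM.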

Compound 4, half-maximal inhibitory concentration: 2250 nM
Estimate against measurement, compound 4: 1.3-fold (0.12 log units) above; the measured number falls inside the stated range.
By their numbers in this assay, from the lowest: compound 1; then compound 4; then compound 2. At a limit, above all of these: compound 3.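

In this assay, within the data shown here, this is the first measured change at this place, on an aromatic carbon of the six-membered aromatic ring with 1 nitrogen, and replacing 1-methyl-1H-1,2,4-triazol-5-yl with 4-(2-(dimethylamino)ethyl)-4H-1,2,4-triazol-3-yl gives an at least 44-fold lower number from compound 3 to compound 4 (1.64 log units; beyond the scatter), with the unsubstituted phenyl held constant. As far as these compounds go, the number for compound 3 is a limit and not a value, so the full size of this step stays unknown: the limit of > 100000 nM in this assay, at which 1 of the 4 values shown sits. The unsubstituted phenyl also gives the aryl ring a reference point, and the two substituents part in direction, with a 2.7-fold higher number from compound 1 to compound 4 (0.43 log units; beyond the scatter) for hydrogen in place of bromo and a 3.2-fold lower number from compound 2 to compound 4 (0.50 log units; beyond the scatter) for hydrogen in place of nitrooxy, both modest beside the triazole change.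

The step alters the triazole attachment and the side chain together, so the compounds shown do not tell which of the two carries it; a 4-methyl-4H-1,2,4-triazol-3-yl group would separate them. From the compounds shown here alone, it also remains open whether the dimethylamino group itself matters, as a 2-(morpholin-4-yl)ethyl chain or a longer chain ending in the same amine could show.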